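The compounds below may be only part of what the source reports. "The series", "measured", "known", "first", "only" and "open" are said of these compounds alone.

Measured in an assay on isolated protein for inhibition of vitamin D3 receptor (Homo sapiens), read by fluorescence polarization; a higher number here means a weaker inhibitor, a lower number a stronger inhibitor: compound 1 `CN(Cc1cccc(F)c1)C(=O)CCCNC(=O)c1ccc(S(C)(=O)=O)c([N+](=O)[O-])c1` gives > 60000 nM, which is a limit of the assay and not a number. Compound 2 `Cc1ccc(N2CCN(C(=O)C3CCN(C(=O)c4ccc(S(C)(=O)=O)c([N+](=O)[O-])c4)CC3)CC2)cc1` gives > 60000 nM, likewise a limit. Compound 3 `CS(=O)(=O)c1ccc(C(=O)N2CCC(C(=O)N(Cc3ccccc3)Cc3ccccc3)CC2)cc1[N+](=O)[O-]` gives > 60000 nM, also a limit.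

Compound 1 therefore stands only at a limit in this assay, as do the two other values shown, all sitting at the limit of > 60000 nM in this assay, at which 3 of the 3 values shown sit. Compound 4 `CN(Cc1ccccc1F)C(=O)CCCNC(=O)c1ccc(S(C)(=O)=O)c([N+](=O)[O-])c1` differs from compound 1 by 2-fluorophenyl in place of 3-fluorophenyl on a saturated chain carbon bound to an amide-type nitrogen. No step between measured compounds is available, so no size for this change can be read from a shown pair. Since compound 1 sits at the limit > 60000 nM, compound 4 is expected to stay near that limit. The expected step from compound 1 to compound 4 is a step that the limit leaves unreadable from compound 1 to compound 4, not beyond the scatter. Compound 4 is estimated at 80000 nM, between 30000 nM and 300000 nM.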

Compound 4, half-maximal inhibitory concentration: > 60000 nM
Compound 4 ended at the assay's limit (the forecaster's own chance of this, stated with the estimate: 85%); the middle value lies beyond the limit too.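

No step can be read from compound 1 to compound 4, since both stand only at a limit of the assay: the limit of > 60000 nM in this assay, at which 4 of the 4 values shown sit.

The compounds shown leave open whether 2-fluorophenyl in place of 3-fluorophenyl changes inhibition at all, and which structures would give a readable value.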